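The source may hold more compounds than are shown below. What is called first, only, known or untested is meant among the compounds shown, and "the series" means these compounds.

Series notes. Compound 1 `CCCS(=O)(=O)Nc1ccc(F)c(C(=O)c2n[nH]c3ncc(-c4cccc(C)c4)cc23)c1F` carries a 3-methylphenyl on the shared core, and in an assay for binding affinity to dual specificity mitogen-activated protein kinase kinase 4 (Homo sapiens), read by KINOMEscan, tested at 100 nM (on this read-out lower numbers stand for a stronger effect and higher numbers for a weaker effect at the one concentration tested), compound 1 gives 15%. Compound 2 `CCCS(=O)(=O)Nc1ccc(F)c(C(=O)c2n[nH]c3ncc(-c4cccc(O)c4)cc23)c1F` carries 3-hydroxyphenyl in its place; in this assay compound 2 gives 2.2%, a step of a number 12.8 percentage points lower from compound 1 to compound 2 (beyond the scatter). Compound 3 `CCCS(=O)(=O)Nc1ccc(F)c(C(=O)c2n[nH]c3ncc(-c4ccc(S(N)(=O)=O)cc4)cc23)c1F` carries 4-sulfamoylphenyl; in this assay compound 3 gives 0.25%. Against compound 1 this reads a number 14.8 percentage points lower from compound 1 to compound 3 (beyond the scatter), against compound 2 only a number 2 percentage points lower from compound 2 to compound 3 (within the scatter). On the three numbers seen so far compound 3 stands lowest, but it cannot be separated from compound 2, only from compound 1.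

Compound 4 `CCCS(=O)(=O)Nc1ccc(F)c(C(=O)c2n[nH]c3ncc(-c4ccc(S(=O)(=O)NCC)cc4)cc23)c1F` is the next step from compound 3: ethyl in place of hydrogen on a sulfonamide nitrogen. Within the data shown here, none of the measured steps touches the sulfonamide nitrogen; all three alter the aryl group on the core, so no step bears directly on this change. Among the measured compounds shown here, the two steps beyond the scatter, a number 12.8 percentage points lower from compound 1 to compound 2 (beyond the scatter) and a number 14.8 percentage points lower from compound 1 to compound 3 (beyond the scatter), were both modest, and the one step within the low-reading pair, a number 2 percentage points lower from compound 2 to compound 3 (within the scatter), stayed within the scatter. With nothing directly comparable, the expected step in this assay is none beyond the scatter, allowing for a somewhat higher number. Compound 4 is therefore estimated at 1%, range 0.1% to 8%, an expected step of a number 0.8 percentage points higher from compound 3 to compound 4 (within the scatter).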

Compound 4, a percentage reported as activity, at one concentration (the size of the read-out at that concentration, not a potency): 3%
For compound 4 the middle estimate is 2 percentage points below the measured one, within the range that was stated.
By their numbers in this assay, from the lowest: compounds 3, 2 and 4 (each within the scatter of the next); then compound 1.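

In this assay, ethyl in place of hydrogen on the sulfonamide nitrogen gives a step of (a number 2.8 percentage points higher from compound 3 to compound 4 (within the scatter)), so this nitrogen takes ethyl with no change that can be told from the scatter. The change from 4-sulfamoylphenyl to 4-(ethylsulfamoyl)phenyl therefore leaves the compound with the low-reading members of the series: the comparison with the 3-hydroxyphenyl compound reads (a number 0.8 percentage points higher from compound 2 to compound 4 (within the scatter)), while the comparison with the 3-methylphenyl compound reads (a number 12 percentage points lower from compound 1 to compound 4 (beyond the scatter)) and remains a modest step. Nothing available on these compounds accounts for the readings at this nitrogen.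

As far as these compounds go, whether this nitrogen also tolerates a longer chain such as butyl, a second ethyl, or a chain ending in an amine or a carboxylic acid remains open. Also open, from the compounds shown here alone, is whether compound 2, compound 3 and compound 4 would come apart at a concentration other than the single one read here, since at this one they lie within the scatter of each other.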